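Amino in Place of Chloro: A Second Test

The source may hold more compounds than are shown below. What is called first, only, known or untested is meant among the compounds shown, and "the series" means these compounds.

Measured compounds:
compound 1 `Nc1nc(Cl)c2ncn(Cc3ccc(CCl)cc3)c2n1` gives 10900 nM
compound 2 `ClCc1cccc(Cn2cnc3c(Cl)nc(Cl)nc32)c1` gives 2690 nM
compound 3 `ClCc1ccc(Cn2cnc3c(Cl)nc(Cl)nc32)cc1` gives 22400 nM

These values come from a functional assay on NCI-H522 cells (Homo sapiens) for cytotoxicity, read by sulforhodamine B assay, with a stated time of 48 h; on this read-out higher numbers stand for weaker inhibition of growth and lower numbers for stronger inhibition of growth. Compound 2 has the lowest number of the three, and its gaps to compound 1 and compound 3 both lie beyond the scatter. Compound 3 and compound 2 share the same atoms joined differently; the difference between the two cores is not broken down here.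

One change has already been measured once: going from compound 3 to compound 1, the change is amino in place of chloro on an aromatic carbon, and the step was a 2.1-fold lower number from compound 3 to compound 1 (0.31 log units; beyond the scatter).

Compound 4 `Nc1nc(Cl)c2ncn(Cc3cccc(CCl)c3)c2n1` is not yet measured. It differs from compound 2 by amino in place of chloro on an aromatic carbon, the same change, at a place described in exactly the same words. Among the measured compounds shown here, the expectation for compound 4 therefore rests on the single earlier step of a 2.1-fold lower number from compound 3 to compound 1 (0.31 log units; beyond the scatter), so a step of about a 2.1-fold lower number from compound 2 to compound 4 (0.32 log units; beyond the scatter) is expected in this assay. On that basis compound 4 is estimated at 1300 nM, most likely between 600 nM and 3000 nM.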

Compound 4, concentration for 50% growth inhibition: 3310 nM
Estimate against measurement, compound 4: 2.5-fold (0.41 log units) below, outside the stated range (above it).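

Amino in place of chloro on the core of compound 2 gives a 1.2-fold higher number from compound 2 to compound 4 (0.09 log units; within the scatter), so on this core the swap has no effect that can be told apart from the normal spread of repeated measurements. Set beside the earlier step on the other core, the new step is not shown to differ from it: the same change on two cores in this assay, a 2.1-fold lower number (0.31 log units; beyond the scatter) from compound 3 to compound 1 and a 1.2-fold higher number (0.09 log units; within the scatter) from compound 2 to compound 4, 2.5-fold (0.40 log units) apart, within the scatter of two such steps. The two cores therefore cannot be said to respond differently, but they are not shown to respond alike either, and two steps are too few to fix the size of this change or to show that it carries over to further cores.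

The compounds shown leave open what other groups would do on the aromatic carbon between two ring nitrogen atoms, such as a methylamino group or a methoxy group. They also leave open whether the same swap would give a clearer step at the chloro group that compound 1 and compound 4 keep.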